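The source may hold more compounds than are shown below. What is called first, only, known or untested is meant among the compounds shown, and "the series" means these compounds.

The measured compounds:
compound 1, `O=C(CCSc1nnc(-c2ccncc2)s1)Nc1ccc(Cl)cc1`, 8210 nM
compound 2, `CC(CSc1nnc(-c2ccncc2)s1)C(=O)Nc1ccc(Cl)cc1`, > 50000 nM

In an ADME assay on BHK-21 cells (Mesocricetus auratus) for cytotoxicity, with a stated time of 3 days (a higher number here means that more compound is tolerated, a lower number that less compound is tolerated), compound 1 gives 8210 nM. Compound 2 reaches only a limit of the assay, > 50000 nM. Among the two results, compound 1 therefore holds the only true number, the other value being a limit (the limit of > 50000 nM in this assay, at which 1 of the 2 values shown sits). The unmeasured compound 3 `O=C(CCSc1nnc(-c2ccncc2)s1)NCc1ccc(Cl)cc1` differs from compound 1 by 4-chlorobenzyl in place of 4-chlorophenyl on an amide-type nitrogen. Among the measured compounds shown here, the single measured step, an at least 6.0-fold higher number from compound 1 to compound 2 (0.78 log units; beyond the scatter), concerns a methyl on the chain and leaves the group on the amide-type nitrogen untouched, so no measured step speaks to the change from compound 1 to compound 3. With nothing pointing in either direction, the expectation for compound 3 is a step of about a 1.1-fold higher number from compound 1 to compound 3 (0.04 log units; within the scatter), which stays within the scatter. Compound 3 is thus estimated at 9000 nM, with a range from 3000 nM to 40000 nM.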

Compound 3, half-maximal cytotoxic concentration: 21500 nM
The estimate for compound 3 lay 2.4-fold (0.38 log units) below the measured number; low and high end bracket the measured number.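

The group on the amide-type nitrogen matters as well: in this assay, 4-chlorobenzyl in place of 4-chlorophenyl gives a 2.6-fold higher number from compound 1 to compound 3 (0.42 log units; beyond the scatter), a modest step. Among the compounds shown here, until now, the only measured change was the methyl on the chain of compound 2, so this is the first sign that cell tolerance also shifts at this other end of the molecule, with the shared core unchanged. Nothing measured here explains why the 4-chlorobenzyl group gives this step.

On these data alone, it remains open whether a longer chain between the amide-type nitrogen and the chlorinated ring would shift the number further, or whether an amine or a carboxylic acid at this place would do the same. Also open, as far as these compounds go, is how the chain methyl of compound 2 and the 4-chlorobenzyl group of compound 3 would behave together in one molecule.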